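The source may report more compounds than this note shows. Statements on the series, on what has been measured and on what is new or still open speak of the compounds shown alone.

Measured so far in an ADME assay on CCRF-CEM cells (Homo sapiens) for cytotoxicity, with a stated time of 5 days; on this read-out lower numbers stand for stronger inhibition and higher numbers for weaker inhibition:
- compound 1 `C=CCN(C)c1nc(N)nc2c1ncn2[C@H]1C[C@H](N=[N+]=[N-])[C@@H](CO)O1`: 27000 nM
- compound 2 `CNc1nc(Cl)nc2c1ncn2[C@H]1C[C@H](N=[N+]=[N-])[C@@H](CO)O1`: > 100000 nM

Within the data shown here, compound 1 gives 27000 nM in this assay, the only number recorded for the series. Compound 2 returns a limit of the assay, > 100000 nM, not a number. That value sits at the limit of > 100000 nM in this assay, at which 1 of the 2 values shown sits. Among the measured compounds shown here, compound 1 therefore stands alone as the single measured point with a number, with no second number to rank it against, and no step between two measured compounds exists here.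

Compound 3 `[N-]=[N+]=N[C@H]1C[C@H](n2cnc3c(NCCCCCO)nc(N)nc32)O[C@@H]1CO` is not yet measured. Against compound 1 it shows ((5-hydroxypentyl)amino in place of allyl(methyl)amino on an aromatic carbon).

For the measured compounds named here, with no measured step to lean on, the expectation rests on compound 1 alone. The step from compound 1 to compound 3 is expected to be small, a 1.5-fold higher number from compound 1 to compound 3 (0.17 log units; within the scatter), a shift toward weaker inhibition not much beyond the scatter. Compound 3 is estimated at 40000 nM, with a range from 12000 nM to 140000 nM.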

Compound 3, half-maximal inhibitory concentration: > 100000 nM
Compound 3: only a limit was reported; the forecaster's own chance of this, stated with the estimate: 35%; middle value at least 2.5-fold (0.39 log units) away from the limit.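

In this assay compound 3 gives > 100000 nM, which is a limit of the assay and not a number. Among these compounds, the aromatic carbon carrying the allyl(methyl)amino group does respond to its substituent: exchanging that group for (5-hydroxypentyl)amino gives an at least 3.7-fold higher number from compound 1 to compound 3 (0.56 log units; beyond the scatter), the first readable step, in the direction of weaker inhibition. Only a lower bound on the size of this step is available, and compound 1 remains the only compound shown with a number.

Going by these compounds, how far the series can be ranked stays open, as most of the data rest on one ceiling: the limit of > 100000 nM in this assay, at which 2 of the 3 values shown sit. On these data alone, it is also open whether the shift follows the hydroxyl, the chain length or the loss of the allyl and methyl groups; a plain pentylamino or a dimethylamino group on the same carbon would separate these.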